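The source may hold more compounds than are shown below. What is called first, only, known or untested is meant among the compounds shown, and "the series" means these compounds.

The compounds share one core, shown in compound 1 `CC(C)(C)N1C[C@@H](C(=O)Nc2ncnn2Cc2ccccc2)[C@H](c2ccc(F)cc2F)C1`, compound 2 `CC(C)(C)N1C[C@@H](C(=O)Nc2nccn2Cc2cccc(Cl)c2)[C@H](c2ccc(F)cc2F)C1`, compound 3 `CC(C)(C)N1C[C@@H](C(=O)Nc2nccn2Cc2ccccc2-c2ccccc2)[C@H](c2ccc(F)cc2F)C1` and the still unmeasured compound 4 `CC(C)(C)N1C[C@@H](C(=O)Nc2nccn2Cc2ccccc2Cl)[C@H](c2ccc(F)cc2F)C1`; they differ only in the group carried on the saturated chain carbon bound to an aromatic nitrogen. In a functional assay for agonist activity at Melanocyte-stimulating hormone receptor (Homo sapiens), read by cAMP accumulation (on this read-out higher numbers stand for an effect only at larger amounts of compound and lower numbers for an effect already at smaller amounts), compound 1 reaches only a limit, > 10000 nM, which is the limit of > 10000 nM in this assay, at which 1 of the 3 values shown sits. In this assay compound 2 gives 1270 nM, and compound 3 gives 527 nM. Of the two numbers on hand, compound 2 therefore stands highest, with compound 3 its nearest neighbour: a 2.4-fold lower number from compound 2 to compound 3 (0.38 log units; beyond the scatter).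

Compound 4 differs from compound 2 in that (2-chlorophenyl in place of 3-chlorophenyl on a saturated chain carbon bound to an aromatic nitrogen). Within the data shown here, the only measured step that bears on this change is a 2.4-fold lower number from compound 2 to compound 3 (0.38 log units; beyond the scatter), which also left the 3-chlorophenyl; it was modest though beyond the scatter. Among the measured compounds shown here, no measured pair contains the 2-chlorophenyl itself, so the expectation rests on that single step, and it points to a small drop at most. The step is estimated as a 1.6-fold lower number from compound 2 to compound 4 (0.20 log units; within the scatter). In this assay compound 4 is therefore expected at 800 nM, within a range from 300 nM to 2500 nM.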

Compound 4, half-maximal effective concentration: 1270 nM
Compound 4: the middle estimate sits 1.6-fold (0.20 log units) below what was measured, within the range that was stated.
By their numbers in this assay, from the lowest: compound 3; then compounds 2 and 4 (each within the scatter of the next). At a limit, above all of these: compound 1.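

Setting the 2-chlorophenyl in place of the 3-chlorophenyl on the saturated chain carbon bound to an aromatic nitrogen gives no change at the digits printed from compound 2 to compound 4 (within the scatter) in this assay, so the two chlorophenyl groups cannot be told apart at this position. Setting chloro in place of phenyl on an aromatic carbon gives a 2.4-fold higher number from compound 3 to compound 4 (0.38 log units; beyond the scatter), a modest step, but one that shows the 2-phenylphenyl group remains separated from both chlorophenyl groups and that, among these three, a change of substituent registers where a shift of the chlorine does not. The data at hand give no reason for either step.

The compounds shown leave open whether an amine, a carboxylic acid or a methoxy group on this phenyl ring would fall with the two chlorophenyl groups or with the 2-phenylphenyl group. From the compounds shown here alone, it also stays open whether a benzyloxy group or a longer chain between the aromatic nitrogen and the phenyl ring would lower the number further.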